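Swapping 2,4-dichlorophenyl for 3-nitrophenyl on the chain

This account rests on a few compounds, and the source may have more. Where it says the series, first, only, none or still open, it means among the compounds named here.

In a functional assay on HepG2 cells (Homo sapiens) for cytotoxicity, read by MTT assay, with a stated time of 72 h (a lower number here means a stronger inhibitor, a higher number a weaker inhibitor), compound 3 `CNC(=O)c1cc(Oc2ccc(C(=O)/C=C/c3ccc(Cl)cc3Cl)cc2)ccn1` gives 11700 nM and compound 1 `CNC(=O)c1cc(Oc2ccc(C(=O)/C=C/c3ccc(Cl)c(Cl)c3)cc2)ccn1` gives 11400 nM, with a 1.0-fold higher number from compound 1 to compound 3 (0.01 log units; within the scatter). Compound 2 `CNC(=O)c1cc(Oc2ccc(C(=O)/C=C/c3ccc(C#N)cc3)cc2)ccn1` gives 5430 nM, and compound 3 stands modestly apart from it, with a 2.2-fold higher number from compound 2 to compound 3 (0.33 log units; beyond the scatter).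

Compound 4 `CNC(=O)c1cc(Oc2ccc(C(=O)/C=C/c3cccc([N+](=O)[O-])c3)cc2)ccn1` carries 3-nitrophenyl in place of 2,4-dichlorophenyl on a double-bonded chain carbon bound to a double-bonded chain carbon. Within the data shown here, no measured compound carries a nitro group, so the closest guide is compound 2, the only measured compound without chlorine, reached by a 2.1-fold lower number from compound 1 to compound 2 (0.32 log units; beyond the scatter). A modest step to a lower number is therefore expected in this assay, though none beyond the scatter remains possible. The estimated change is a 1.7-fold lower number from compound 3 to compound 4 (0.22 log units; within the scatter). For compound 4 the expected value is 7000 nM, with an estimated range of 3000 nM to 15000 nM.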

Compound 4, half-maximal inhibitory concentration: > 50000 nM
Compound 4 ended at the assay's limit; the forecaster's own chance of this, stated with the estimate: 2%; middle value at least 7.1-fold (0.85 log units) from the limit.
By their numbers in this assay, from the lowest: compound 2; then compounds 1 and 3 (each within the scatter of the next). At a limit, above all of these: compound 4.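

In this assay compound 4 stands at a limit, not a number: the limit of > 50000 nM in this assay, at which 1 of the 4 values shown sits.

The widest earlier step on this chain carbon was a 2.2-fold higher number from compound 2 to compound 3 (0.33 log units; beyond the scatter). Placing 3-nitrophenyl here gives an at least 4.2-fold higher number from compound 3 to compound 4 (0.63 log units; beyond the scatter), an at least 4.3-fold higher number from compound 1 to compound 4 (0.64 log units; beyond the scatter) and an at least 9.2-fold higher number from compound 2 to compound 4 (0.96 log units; beyond the scatter), so the aryl group at this place can move the value further than the earlier compounds showed.

The compounds shown do not separate the nitro group from its place on the ring. An amine in that same place would show whether the step follows the nitro group or the substitution site.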